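The compounds below may be only part of what the source reports. "The series", "measured", "known", "first", "only" and "open" are said of these compounds alone.

The compounds here share one core and differ in the aromatic group on a double-bonded chain carbon bound to a double-bonded ring carbon. In a functional assay on MCF7 cells (Homo sapiens) for cytotoxicity, read by MTT assay, with a stated time of 72 h (on this read-out lower numbers stand for stronger inhibition and higher numbers for weaker inhibition), compound 3 `COc1cccc(C=C2C(=O)N(c3ccc(Cl)cc3)N(c3ccc(Cl)cc3)C2=O)c1` gives 18100 nM and compound 2 `O=C1C(=Cc2cccc(Cl)c2)C(=O)N(c2ccc(Cl)cc2)N1c1ccc(Cl)cc1` gives 18300 nM. Between these two numbers lies a 1.0-fold lower number from compound 2 to compound 3 (0.00 log units; within the scatter), so compound 3 stands level with compound 2. Compound 1 `COc1ccc(C=C2C(=O)N(c3ccc(Cl)cc3)N(c3ccc(Cl)cc3)C2=O)cc1` gave only a limit of the assay, > 128000 nM.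

The next compound is compound 4 `COc1ccccc1C=C1C(=O)N(c2ccc(Cl)cc2)N(c2ccc(Cl)cc2)C1=O`, in which 2-methoxyphenyl replaces 3-methoxyphenyl: 2-methoxyphenyl in place of 3-methoxyphenyl on a double-bonded chain carbon bound to a double-bonded ring carbon. The nearest measured change is an at least 7.0-fold lower number from compound 1 to compound 3 (0.84 log units; beyond the scatter), which shows that swapping one methoxyphenyl group for another can matter in this assay. Its companion, an at least 6.9-fold lower number from compound 1 to compound 2 (0.84 log units; beyond the scatter), is of the same size. Neither step involves 2-methoxyphenyl, so neither fixes a direction for this change. The best expectation is therefore no step beyond the scatter, with a slight lean towards a higher number and a wide margin. The expected change is a 1.4-fold higher number from compound 3 to compound 4 (0.14 log units; within the scatter). For compound 4 the estimate is 25000 nM, with an expected range from 8000 nM to 80000 nM.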

Compound 4, half-maximal inhibitory concentration: 26300 nM
For compound 4 the middle estimate is 1.1-fold (0.02 log units) below the measured one; measured number inside the range.
By their numbers in this assay, from the lowest: compounds 3, 2 and 4 (each within the scatter of the next). At a limit, above all of these: compound 1.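

In this assay, the new group gives a 1.5-fold higher number from compound 3 to compound 4 (0.16 log units; within the scatter) and a 1.4-fold higher number from compound 2 to compound 4 (0.16 log units; within the scatter), so at this position 2-methoxyphenyl cannot be told apart from 3-methoxyphenyl or 3-chlorophenyl. Among the methoxyphenyl groups, only 4-methoxyphenyl now stands apart, with an at least 4.8-fold lower number from compound 1 to compound 4 (0.68 log units; beyond the scatter), and the true size of that step remains unknown. Compound 1 gives only a limit, not a number: the limit of > 128000 nM in this assay, at which 1 of the 4 values shown sits.

Going by these compounds, it remains open whether 4-chlorophenyl at this place would also end at a limit, which would show whether the gap follows the 4-substitution itself or the methoxy group in particular. Also open, on these data alone, is how an aromatic group carrying an amine or a carboxylic acid would read in this assay.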